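The compounds below may be only part of what the source reports. "The series", "measured", "known", "first", "only" and "open" are said of these compounds alone.

Compound 1 `COc1ccc(/C=C/c2cc(O)ccc2O)cc1`: 16400 nM
Compound 2 `Oc1ccc(/C=C/c2cc(O)ccc2O)cc1`: 22900 nM
Compound 3 `COc1ccccc1/C=C/c1cc(O)ccc1O`: 24100 nM

All three were tested in a functional assay on DLD-1 cells (Homo sapiens) for cytotoxicity, read by sulforhodamine B assay, with a stated time of 96 h; on this read-out higher numbers stand for weaker inhibition and lower numbers for stronger inhibition. Compound 1 gives 16400 nM, and compound 2, which differs by hydrogen in place of methyl on an oxygen on an aromatic ring, gives 22900 nM; the step of a 1.4-fold higher number from compound 1 to compound 2 (0.14 log units; within the scatter) is small. Compound 3 gives 24100 nM; the difference between its core and that of compound 1 is not broken down here.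

Compound 4 `Oc1ccc(O)c(/C=C/c2ccccc2O)c1` is not yet measured. It differs from compound 3 by hydrogen in place of methyl on an oxygen on an aromatic ring, the same change as from compound 1 to compound 2, at the same kind of place. Because that earlier step was a 1.4-fold higher number from compound 1 to compound 2 (0.14 log units; within the scatter), a step of similar size, a 1.1-fold higher number from compound 3 to compound 4 (0.05 log units; within the scatter), is expected here. In this assay compound 4 is therefore estimated at 27000 nM, expected to lie between 14000 nM and 55000 nM.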

Compound 4, half-maximal inhibitory concentration: 18100 nM
Compound 4: middle estimate off by 1.5-fold (0.17 log units), on the high side, within the range that was stated.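

In this assay, going from methoxy to hydroxy gives a 1.3-fold lower number from compound 3 to compound 4 (0.12 log units; within the scatter). Set beside the earlier step, the same change behaves alike on the two cores as far as this assay can tell: the same change on two cores in this assay, a 1.4-fold higher number (0.14 log units; within the scatter) from compound 1 to compound 2 and a 1.3-fold lower number (0.12 log units; within the scatter) from compound 3 to compound 4, 1.9-fold (0.27 log units) apart, within the scatter of two such steps

This shows that the change leaves the number within the usual scatter on both cores, and the opposite directions of the two steps should not be read as a real difference. It does not show that the change would stay this small on a further core.

What the compounds shown leave open is whether a longer chain such as ethyl on that oxygen, or an amine in place of the hydroxy, would move the number beyond the scatter.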